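Thiourea Series: From Compound 1 Toward Compound 3

A few compounds are considered here, and "the series" means these few. Any claim that something is new, unique, unknown or untested is made for them only; others in the source may bear on it.

Compound 1 `COc1ccccc1NC(=S)NC1CC(C)(C)Oc2ccc(Br)cc21` was run in a functional assay on B16-F10 cells (Mus musculus) for inhibition, read by MTT assay, with a stated time of 72 h (a lower number here means a stronger inhibitor, a higher number a weaker inhibitor), but returned only "not determined" (no result reported), so compound 1 has no number to stand on. Its companion compound 2 `CC1(C)CC(NC(=S)Nc2ccc([N+](=O)[O-])cc2)c2cc(Cl)ccc2O1` gives 3000 nM in this assay and is the only anchor here. Compound 3 `CC1(C)CC(NC(=S)Nc2cccc(C#N)c2)c2cc(Br)ccc2O1` arises from compound 1 by one change: 3-cyanophenyl in place of 2-methoxyphenyl on an amide-type nitrogen. Among the compounds with values here, with no measured step between these two compounds, the direction of change in this assay cannot be fixed, and a step of no more than a modest size in either direction is expected. Compound 3 is estimated at 3000 nM, between 700 nM and 13000 nM.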

Compound 3, half-maximal inhibitory concentration: 7000 nM
Beside the measured number, compound 3's estimate is 2.3-fold (0.37 log units) below it, and the stated range covers the measured number.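

In this assay, within the data shown here, compound 1 carries no number, and no step from it to compound 3 can be read. Going by these compounds, the effect of exchanging 2-methoxyphenyl for 3-cyanophenyl therefore stays open, and nothing available bears on this result.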